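Methyl for Trifluoromethyl on the Aryl Piperazine

The source may report more compounds than this note shows. Statements on the series, on what has been measured and on what is new or still open speak of the compounds shown alone.

Measured compounds:
compound 1, `CC1CC(=O)N(CC(=O)N2CCN(c3ccccc3)CC2)C1=O`: 300 mg/kg
compound 2, `Cc1ccccc1N1CCN(C(=O)CN2C(=O)CC(C)C2=O)CC1`: 100 mg/kg
compound 3, `CC1CC(=O)N(CC(=O)N2CCN(c3cccc(C(F)(F)F)c3)CC2)C1=O`: 300 mg/kg

In a functional assay on the whole organism (strain CD1) with Mus musculus as the target, with a stated time of 0.5 h (a lower number here means that less compound is needed, a higher number that more compound is needed for the effect), compound 3 stands level with compound 1, and together they give the highest of the three numbers; the only lowering beyond the scatter is a 3.0-fold lower number from compound 1 to compound 2 (0.48 log units; beyond the scatter). Compound 4, `Cc1cccc(N2CCN(C(=O)CN3C(=O)CC(C)C3=O)CC2)c1`, differs from compound 3 by methyl in place of trifluoromethyl on an aromatic carbon. Within the data shown here, two steps bear on this change. The step of no change at the digits printed from compound 1 to compound 3 (within the scatter) shows trifluoromethyl adding nothing over hydrogen, so its removal should cost nothing. Among the measured compounds shown here, the step of a 3.0-fold lower number from compound 1 to compound 2 (0.48 log units; beyond the scatter) shows a methyl lowering the number modestly, the sole guide for the entering group. A modest lowering is therefore expected, a 2.0-fold lower number from compound 3 to compound 4 (0.30 log units; within the scatter). Compound 4 is estimated at 150 mg/kg, within 70 mg/kg to 300 mg/kg.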

Compound 4, minimum effective dose: 100 mg/kg
Compound 4: middle estimate off by 1.5-fold (0.18 log units), on the high side; measured number inside the range.
By their numbers in this assay, from the lowest: compounds 2 and 4 (each within the scatter of the next); then compounds 1 and 3 (each within the scatter of the next).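

In this assay, methyl on the aromatic carbon meta to a large group gives a 3.0-fold lower number from compound 1 to compound 4 (0.48 log units; beyond the scatter), whereas trifluoromethyl at that carbon had given no such lowering, and the exchange of the two groups gives a 3.0-fold lower number from compound 3 to compound 4 (0.48 log units; beyond the scatter). With 3-methylphenyl in place of 2-methylphenyl there is no change at the digits printed from compound 2 to compound 4 (within the scatter), so the lowering seen with methyl holds at both places. Nothing measured here accounts for this. Going by these compounds, whether chlorine, a methoxy group or a longer chain such as ethyl at this carbon would follow methyl or trifluoromethyl remains open.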